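Methoxy in place of hydroxy at the side-chain tail

The source may hold more compounds than are shown below. What is called first, only, known or untested is meant among the compounds shown, and "the series" means these compounds.

Of the compounds shown here, two have been tested for cytotoxicity. In an ADME assay on MDCK cells (Canis lupus familiaris) for cytotoxicity, read by CellTiter-Glo, with a stated time of 40 h (on this read-out lower numbers stand for higher toxicity in this test and higher numbers for lower toxicity in this test), compound 1 `C=CC(C)(C)c1[nH]c2ccc(C[C@H](O)C(C)(C)OC)cc2c1/C=C1\NC(=O)[C@H](C)NC1=O` gives a limit of the assay, > 200000 nM, and not a number. In this assay compound 2 `C=CC(C)(C)c1[nH]c2c(C[C@H](O)C(C)(C)O)cccc2c1/C=C1\NC(=O)[C@H](C)NC1=O` likewise gives only a limit of the assay, > 200000 nM. On the numbers shown, compound 2 therefore stands where everything else stands, since (the limit of > 200000 nM in this assay, at which 2 of the 2 values shown sit). Among the compounds with values here, no step between the two measured compounds can be read from this, as both values are limits.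

Compound 3 `C=CC(C)(C)c1[nH]c2c(C[C@H](O)C(C)(C)OC)cccc2c1/C=C1\NC(=O)[C@H](C)NC1=O` is not yet measured in this assay. Compared with compound 2, the change is methyl in place of hydrogen on an oxygen on a saturated carbon. This is a small change, a hydroxy becoming a methoxy on the same saturated carbon. Because both measured values sit at the limit of > 200000 nM in this assay, at which 2 of the 2 values shown sit, no step beyond the usual scatter is expected, and the step of a number no higher from compound 2 to compound 3 (the limit leaves the size open) is estimated to be none. In this assay compound 3 is expected to give 200000 nM, with a range from 100000 nM to 400000 nM, most likely as a limit again rather than a number.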

Compound 3, half-maximal cytotoxic concentration: > 200000 nM
Compound 3 ended at the assay's limit; the forecaster's own chance of this, stated with the estimate: 85%; the middle value sits exactly at the limit.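

Within the data shown here, compound 3 gives only a limit of the assay, as compound 2 does, and no step between compound 2 and compound 3 can be read: (the limit of > 200000 nM in this assay, at which 3 of the 3 values shown sit). In this assay none of the compounds shown gives a number, and they leave open what methyl in place of hydrogen on this oxygen does to cytotoxicity.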